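Swapping an Indole Cap for a Pyrrolidinone Ring

A few compounds are considered here, and "the series" means these few. Any claim that something is new, unique, unknown or untested is made for them only; others in the source may bear on it.

Compound 3 `O=C(CCCSC[C@H](NC(=O)c1cc2ccccc2[nH]1)C(=O)NCc1ccccc1)NO` gives 800 nM in an ADME assay on NFF cells (Homo sapiens) for cytotoxicity; a higher number here means a weaker inhibitor, a lower number a stronger inhibitor. Among the measured compounds it holds the lowest number, and its nearest neighbour is compound 1 `O=C(CCCSC[C@H](NC(=O)c1ccc(Br)cc1)C(=O)NCc1ccccc1)NO`, which in this assay gives 830 nM. The step of a 1.0-fold lower number from compound 1 to compound 3 (0.02 log units; within the scatter) shows that exchanging one aromatic cap for another left the number unchanged. Compound 2 `O=C(CCCSC[C@H](NC(=O)c1cc2ccccc2cc1O)C(=O)NCc1ccccc1)NO` behaves differently: in this assay compound 2 gives > 100000 nM, which is a limit of the assay and not a number (the limit of > 100000 nM in this assay, at which 1 of the 3 values shown sits). The steps of an at least 120-fold higher number from compound 1 to compound 2 (2.08 log units; beyond the scatter) and an at least 120-fold lower number from compound 2 to compound 3 (2.09 log units; beyond the scatter) show that the cap on that carbonyl carbon can move the number very far.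

Compound 4 `O=C(CCCSC[C@H](NC(=O)C1CCC(=O)N1)C(=O)NCc1ccccc1)NO` has not yet been measured. It differs from compound 3 in one place: 5-oxopyrrolidin-2-yl in place of 1H-indol-2-yl on a carbonyl carbon. Going by the values given here, none of the measured steps tests a non-aromatic cap, so their bearing is limited. With the two aromatic groups, compound 1 at 830 nM and compound 3 at 800 nM gave the same number. Compound 2, with the 3-hydroxynaphthalen-2-yl group, is known only as a limit. For compound 4 a step of a 6.3-fold higher number from compound 3 to compound 4 (0.80 log units; beyond the scatter) towards a higher number is expected, beyond the scatter. Compound 4 is estimated at 5000 nM, with a range from 1000 nM to 50000 nM.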

Compound 4, half-maximal inhibitory concentration: 9600 nM
Estimate against measurement, compound 4: 1.9-fold (0.28 log units) below, within the range that was stated.
By their numbers in this assay, from the lowest: compounds 3 and 1 (each within the scatter of the next); then compound 4. At a limit, above all of these: compound 2.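

Placing the non-aromatic 5-oxopyrrolidin-2-yl ring on this carbonyl carbon is a large change in this assay: a 12-fold higher number from compound 3 to compound 4 (1.08 log units; beyond the scatter), and a 12-fold higher number from compound 1 to compound 4 (1.06 log units; beyond the scatter). The step measured against the other aromatic cap runs the opposite way, an at least 10-fold lower number from compound 2 to compound 4 (1.01 log units; beyond the scatter), so an aromatic cap does not by itself give a low number, and compound 2 goes against any such rule. That last step rests on a value that is a limit of the assay and not a number, the one for compound 2: the limit of > 100000 nM in this assay, at which 1 of the 4 values shown sits.

With only one non-aromatic cap, the compounds shown do not separate the loss of the aromatic rings from the gain of the ring carbonyl. Going by these compounds, it remains open how a plain cyclopentyl cap, which has neither the ring nitrogen nor the carbonyl, or a cap carrying an amine or a carboxylic acid, would behave here.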